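The source may report more compounds than this note shows. Statements on the series, on what has been measured and on what is new or still open speak of the compounds shown alone.

Measured so far:
compound 1 `Cc1ccc2c(C3CCN(CCN4CCN(C(C)C)C4=O)CC3)cn(-c3ccc(F)cc3)c2c1` — 85 nM
compound 2 `Cc1ccc2c(C3CCN(CCN4CCNC4=O)CC3)cn(-c3ccc(F)cc3)c2c1` — 24 nM
compound 3 `CC(C)N1CCN(CCN2CCC(c3cn(-c4ccc(F)cc4)c4cc(F)ccc34)CC2)C1=O` — 13 nM

Of the compounds shown here, three sharing one core have been tested in an assay on cell membranes for displacement of a labelled ligand from Adrenergic receptor alpha-1 (Rattus norvegicus); a higher number here means a weaker inhibitor, a lower number a stronger inhibitor. Compound 2 stands second highest of the three numbers. Its nearest neighbour is compound 3, whose number sits within the scatter of that of compound 2, so the two cannot be told apart. Compound 1 stands clearly apart: the step of a 3.5-fold lower number from compound 1 to compound 2 (0.55 log units; beyond the scatter) shows that removing the isopropyl from the ring nitrogen brings the number down.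

Compound 4 `CC(C)c1ccc2c(C3CCN(CCN4CCNC4=O)CC3)cn(-c3ccc(F)cc3)c2c1` has not yet been measured. It differs from compound 2 in one place: isopropyl in place of methyl on an aromatic carbon. Among the compounds with values here, two measured steps bear on this. The step of a 6.5-fold lower number from compound 1 to compound 3 (0.82 log units; beyond the scatter) changed the group at this same aromatic carbon, swapping methyl for fluoro, and moved the number modestly downward. The step of a 3.5-fold lower number from compound 1 to compound 2 (0.55 log units; beyond the scatter) involved an isopropyl, though on an amide-type nitrogen rather than an aromatic carbon, and also moved the number downward when the isopropyl left. Neither step matches the present change exactly, so no large shift is expected in this assay.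

Compound 4 is therefore expected to give about 32 nM, with a range from 10 nM to 100 nM. This estimate means a step of a 1.3-fold higher number from compound 2 to compound 4 (0.12 log units; within the scatter), which is expected to stay within the scatter.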

Compound 4, half-maximal inhibitory concentration: 250 nM
For compound 4 the middle estimate is 7.8-fold (0.89 log units) below the measured one, outside the stated range (above it).
By their numbers in this assay, from the lowest: compounds 3 and 2 (each within the scatter of the next); then compound 1; then compound 4.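

Putting isopropyl in place of methyl on this aromatic carbon gives a 10-fold higher number from compound 2 to compound 4 (1.02 log units; beyond the scatter) in this assay, the largest step among the compounds shown. Within the data shown here, until now the only change at this carbon was methyl to fluoro, which lowered the number, so this result adds the opposite direction: the same position can also raise the number sharply, here when a group of 3 heavy atoms replaces one of 1 heavy atom. Thus the group on this carbon has a strong influence on the result, but the data give no measured property that explains the rise.

Going by these compounds, what remains open is how the number changes across other groups on this carbon, such as ethyl, which would show whether it climbs gradually from methyl to isopropyl, or chloro and methoxy, which would extend the comparison beyond simple carbon chains. On these data alone, it is also open whether the same rise would appear in compounds carrying isopropyl on the amide-type nitrogen in the ring, as compound 1 does, since the step seen here comes from a single pair with hydrogen on that nitrogen.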